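Swapping bromo for tert-butoxy on compound 3

The compounds below may be only part of what the source reports. "The series", "measured", "known", "first", "only" and "open" are said of these compounds alone.

Compound 1 `CC(C)(C)Oc1ccc(-c2nnc(SCCCN3CCN(c4nc5ccccc5o4)CC3)o2)cc1`: 263000 nM
Compound 2 `Cc1ccc(-c2nnc(SCCCN3CCN(c4nc5ccccc5s4)CC3)o2)cc1`: 53900 nM
Compound 3 `Brc1ccc(-c2nnc(SCCCN3CCN(c4nc5ccccc5s4)CC3)o2)cc1`: 62500 nM

In a functional assay on A549 cells (Homo sapiens) for inhibition, read by MTT assay, with a stated time of 72 h (a higher number here means a weaker inhibitor, a lower number a stronger inhibitor), compound 3 gives 62500 nM, within the scatter of compound 2 and beyond the scatter of compound 1, which has the highest number of the three. Compound 4 `CC(C)(C)Oc1ccc(-c2nnc(SCCCN3CCN(c4nc5ccccc5s4)CC3)o2)cc1` places tert-butoxy in place of bromo on an aromatic carbon. Going by the values given here, the one measured step at this place, a 1.2-fold higher number from compound 2 to compound 3 (0.06 log units; within the scatter), was small. Compound 1 also carries tert-butoxy, on a core that differs elsewhere, and its 263000 nM leans the expectation slightly upward. The expected change is a 1.4-fold higher number from compound 3 to compound 4 (0.13 log units; within the scatter), which would stay within the scatter. For compound 4 the estimated value is 85000 nM, with an expected range from 40000 nM to 190000 nM.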

Compound 4, half-maximal inhibitory concentration: 71600 nM
For compound 4 the middle estimate is 1.2-fold (0.07 log units) above the measured one, and the stated range covers the measured number.
By their numbers in this assay, from the lowest: compounds 2, 3 and 4 (each within the scatter of the next); then compound 1.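

In this assay tert-butoxy on the aromatic carbon reads the same as bromo (a 1.1-fold higher number from compound 3 to compound 4 (0.06 log units; within the scatter)) and as methyl (a 1.3-fold higher number from compound 2 to compound 4 (0.12 log units; within the scatter)), so this place accepts all three groups without a change beyond the scatter. With tert-butoxy held fixed, the step beyond the scatter comes from the other end of the molecule, 1,3-benzothiazol-2-yl in place of 1,3-benzoxazol-2-yl (a 3.7-fold lower number from compound 1 to compound 4 (0.57 log units; beyond the scatter)), so the high number of compound 1 goes with that swap and not with tert-butoxy. Nothing available here explains either result.

On these data alone, whether an amine or a carboxylic acid at this place would move the number beyond the scatter stays open. So does whether the 1,3-benzoxazol-2-yl swap gives a similar step with bromo or methyl in place of tert-butoxy.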